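The source may hold more compounds than are shown below. What is called first, only, known or untested is meant among the compounds shown, and "the series" means these compounds.

Compound 1, `CC(C)c1onc(-c2ccccc2)c1COc1ccc(Oc2ccc(C(=O)O)cc2)cc1`: 11000 nM
Compound 2, `CC(C)c1onc(-c2ccccc2)c1COc1ccc(COc2ccc(CC(=O)O)cc2)cc1`: 11000 nM

Both were measured in an assay on HEK-293T cells for activation of Bile acid receptor (Homo sapiens), read by a luciferase reporter, with a stated time of 14 h; on this read-out higher numbers stand for an effect only at larger amounts of compound and lower numbers for an effect already at smaller amounts. On these numbers compound 2 stands level with compound 1 at the digits shown; the two values lie within the usual scatter, so nothing separates them.

Compound 3, `CC(C)c1onc(-c2ccccc2)c1COc1ccc(CCCC(=O)O)cc1`, is not yet measured. It differs from compound 2 in one place: 2-carboxyethyl in place of 4-(carboxymethyl)phenoxy on a saturated chain carbon bound to an aromatic carbon. Going by the values given here, no step between measured compounds shows how such a change plays out in this assay, since the only measured pair gives values that agree. The expectation therefore rests on compound 2 alone. Any step is expected to be small, in either direction or none beyond the scatter, with a slight lean toward a larger number. The step of a 1.4-fold higher number from compound 2 to compound 3 (0.13 log units; within the scatter) is the one estimated here. Compound 3 is expected to give 15000 nM in this assay, within a range from 4000 nM to 50000 nM.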

Compound 3, half-maximal effective concentration: 31000 nM
The estimate for compound 3 lay 2.1-fold (0.32 log units) below the measured number, and the stated range covers the measured number.
By their numbers in this assay, from the lowest: compounds 1 and 2 (each within the scatter of the next); then compound 3.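

In this assay, going by these compounds alone, putting the smaller 2-carboxyethyl in place of 4-(carboxymethyl)phenoxy gives a 2.8-fold higher number from compound 2 to compound 3 (0.45 log units; beyond the scatter) and is the first change in this set to move the number beyond the scatter. Measured against the other ring-bearing compound, 3-carboxypropyl in place of 4-carboxyphenoxy on an aromatic carbon gives a 2.8-fold higher number from compound 1 to compound 3 (0.45 log units; beyond the scatter) and points the same way, so both compounds with the second aromatic ring respond at smaller amounts than the compound without it. No measurement at hand gives a reason for this shift.

The change removes the ring and shortens the group together, so these compounds cannot show which of the two matters. On these data alone, it also remains open how a longer saturated chain ending in a carboxylic acid, or an amide at that chain end, would read in this assay on this core.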